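A Hydroxypentyl Carbonate Replaces an Aminopropyl Carbamate

The source may hold more compounds than are shown below. What is called first, only, known or untested is meant among the compounds shown, and "the series" means these compounds.

The two measured compounds share one core; only the chain hanging from the carbonyl carbon changes. Compound 1, `Cc1cn(C2CC(N=[N+]=[N-])C(COC(=O)OCCCCCCO)O2)c(=O)[nH]c1=O`, carries a (6-hydroxyhexyl)oxy group there. In a functional assay on MT4 cells (Homo sapiens) for cytotoxicity (a lower number here means that less compound is tolerated, a higher number that more compound is tolerated), compound 1 gives only a limit, > 50000 nM. Compound 2, `Cc1cn(C2CC(N=[N+]=[N-])C(COC(=O)NCCCN)O2)c(=O)[nH]c1=O`, carries a (3-aminopropyl)amino group instead. In this assay compound 2 likewise gives only a limit, > 50000 nM. The step that the two limits leave unreadable from compound 1 to compound 2 therefore cannot be read; both values sit at the limit of > 50000 nM in this assay, at which 2 of the 2 values shown sit. Compound 3, `Cc1cn(C2CC(N=[N+]=[N-])C(COC(=O)OCCCCCO)O2)c(=O)[nH]c1=O`, brings the change ((5-hydroxypentyl)oxy in place of (3-aminopropyl)amino on a carbonyl carbon). Among the measured compounds shown here, the single measured step gives no sign that a chain of this kind on the carbonyl carbon moves the read-out, and compound 1 already carries the closely related (6-hydroxyhexyl)oxy chain without leaving the limit. No step beyond the scatter is therefore expected, and the estimated step that the limit leaves unreadable from compound 2 to compound 3 means compound 3 is expected to remain at the limit as well. For compound 3 the estimate is 80000 nM, with a range from 40000 nM to 200000 nM.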

Compound 3, half-maximal cytotoxic concentration: > 50000 nM
Compound 3 ended at the assay's limit; the forecaster's own chance of this, stated with the estimate: 85%; the middle value lies beyond the limit too.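

No step among compound 1, compound 2 and compound 3 can be read in this assay, because each gives only a limit: the limit of > 50000 nM in this assay, at which 3 of the 3 values shown sit.

The compounds shown leave open whether these different chains on the carbonyl carbon differ at all in this assay.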